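Amide versus amine on the ring nitrogen of the shared core

The source may hold more compounds than are shown below. What is called first, only, known or untested is meant among the compounds shown, and "the series" means these compounds.

Measured compounds:
- compound 1, `CC(C)CN1CCc2nc(C#Cc3ccccc3)sc2C1`: > 10000 nM
- compound 2, `C(#Cc1nc2c(s1)CN(C1CCCCC1)CC2)c1ccccc1`: > 10000 nM
- compound 3, `COC1CC(C(=O)N2CCc3nc(C#Cc4ccccc4)sc3C2)C1`: 640 nM

All three share one core and differ only in the group on the amine nitrogen in the ring. In an assay on HEK293 cells for positive allosteric modulation of metabotropic glutamate receptor 5 (Homo sapiens), read by FLIPR, with a stated time of 1 h (a lower number here means that less compound is needed, a higher number that more compound is needed for the effect), compound 1 reaches only the limit of the assay, > 10000 nM. Compound 2 likewise gives only a limit in this assay, > 10000 nM. Among the measured compounds shown here, compound 3 is the one compound with a measured number, 640 nM, and therefore stands alone among the values shown. The steps of an at least 15-fold lower number from compound 1 to compound 3 (1.19 log units; beyond the scatter) and an at least 15-fold lower number from compound 2 to compound 3 (1.19 log units; beyond the scatter) are both large, each running from a limit of > 10000 nM in this assay, at which 2 of the 3 values shown sit, to a number. The step that the two limits leave unreadable from compound 1 to compound 2 between the two limits cannot be read.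

Compound 4, `N#Cc1cccc(C(=O)N2CCc3nc(C#Cc4ccccc4)sc3C2)c1`, keeps the carbonyl on that ring nitrogen and changes only the group on the carbonyl carbon: 3-cyanophenyl in place of 3-methoxycyclobutyl on a carbonyl carbon. For the measured compounds named here, no measured step touches this position, so the two large amide steps bear on it only in that the amide itself is retained. No step beyond the scatter is expected from compound 3 to compound 4; a value near that of compound 3 is estimated, with the step of a 1.6-fold lower number from compound 3 to compound 4 (0.20 log units; within the scatter). Compound 4 is thus expected to give about 400 nM in this assay, within 80 nM to 2000 nM.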

Compound 4, half-maximal effective concentration: 71 nM
The estimate for compound 4 lay 5.6-fold (0.75 log units) above the measured number; measured number below the stated range.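

In this assay the group on the carbonyl carbon matters in its own right, with the amide retained throughout (a 9.0-fold lower number from compound 3 to compound 4 (0.95 log units; beyond the scatter)). Among the compounds shown here, the earlier compounds showed only a contrast between amine and amide on the ring nitrogen, whereas this is the first readable step between two amides, and it shows that the carbonyl alone does not set the value. The change is not a single one, however: a four-membered non-aromatic ring leaves, while a six-membered aromatic ring and a triple bond outside aromatic rings enter, so this pair cannot assign the step to either feature.

From the compounds shown here alone, whether the aromatic ring or the nitrile carries the step stays open, and a plain phenyl or a 3-methoxyphenyl on the carbonyl carbon would separate the two. The amine side also remains unresolved, since compound 1 and compound 2 are limits rather than numbers and the step between them cannot be read: the limit of > 10000 nM in this assay, at which 2 of the 4 values shown sit.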